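From a methoxyphenyl group to a pyrrole side chain

The source may hold more compounds than are shown below. What is called first, only, known or untested is meant among the compounds shown, and "the series" means these compounds.

compound 1 `O=C(N/N=C/c1ccccc1)Nc1ccc(Oc2ccnc3[nH]ccc23)cc1`: 750 nM
compound 2 `O=C(N/N=C/c1cccc(Cl)c1Cl)Nc1ccc(Oc2ccnc3[nH]ccc23)cc1`: "not active" (no number reported)
compound 3 `COc1ccc(/C=N/NC(=O)Nc2ccc(Oc3ccnc4[nH]ccc34)cc2)cc1`: 9740 nM

Among the compounds with values here, in a functional assay on HepG2 cells (Homo sapiens) for antiproliferative activity, read by MTT assay, with a stated time of 72 h (on this read-out lower numbers stand for stronger inhibition and higher numbers for weaker inhibition), compound 3 holds the higher of the only two numbers, and compound 2 gave no number. Compound 4 `CN(C)CCCn1cccc1/C=N/NC(=O)Nc1ccc(Oc2ccnc3[nH]ccc23)cc1` differs from compound 3 in one place: 1-(3-(dimethylamino)propyl)-1H-pyrrol-2-yl in place of 4-methoxyphenyl on a carbon with a double bond to nitrogen. In words, 1-(3-(dimethylamino)propyl)-1H-pyrrol-2-yl stands in place of 4-methoxyphenyl on a carbon with a double bond to nitrogen. Within the data shown here, only one measured step bears on this, and only partly: a 13-fold higher number from compound 1 to compound 3 (1.11 log units; beyond the scatter), a large step on adding the methoxy that compound 4 no longer carries. Losing that methoxy may win back part of this step, but the entering group is untested, so the expectation is loose. The expected step, toward a lower number, is a 3.9-fold lower number from compound 3 to compound 4 (0.59 log units; beyond the scatter). For compound 4 the estimated value is 2500 nM, with an expected range from 400 nM to 12000 nM.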

Compound 4, half-maximal inhibitory concentration: 4190 nM
Compound 4: the middle estimate sits 1.7-fold (0.22 log units) below what was measured; the range from low to high includes it.
By their numbers in this assay, from the lowest: compound 1; then compound 4; then compound 3.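

Placing 1-(3-(dimethylamino)propyl)-1H-pyrrol-2-yl on the carbon with a double bond to nitrogen instead of 4-methoxyphenyl gives a 2.3-fold lower number from compound 3 to compound 4 (0.37 log units; beyond the scatter) and so shows that this position can carry a five-membered aromatic ring with a side chain and keep measurable activity. The same group in place of plain phenyl gives a 5.6-fold higher number from compound 1 to compound 4 (0.75 log units; beyond the scatter) and so leaves phenyl the better of these two groups. Still open, on these data alone, is whether the pyrrole ring or its side chain sets this result, and how a pyrrole with a shorter chain or a terminal carboxylic acid would compare. Nothing available here explains either step.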